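Methoxy to Hydroxy on a Shared Core

The compounds below may be only part of what the source reports. "The series", "measured", "known", "first", "only" and "open" are said of these compounds alone.

In a physicochemical assay for solubility, read by spectrophotometry, using the shake flask method, in phosphate buffer, measured as thermodynamic solubility, with a stated time of 72 h, at pH 7.4 (on this read-out lower numbers stand for lower solubility and higher numbers for higher solubility), compound 1 `C=C1CN(S(=O)(=O)c2ccc(C)cc2)CCc2cc(C(C)(C)C)cc(n2)CCN(S(=O)(=O)c2ccc(C)cc2)C1` gives 20000 nM, compound 2 `C=C1CN(S(=O)(=O)c2ccc(C)cc2)CCc2cc(CCC)cc(n2)CCN(S(=O)(=O)c2ccc(C)cc2)C1` gives 18000 nM and compound 3 `C=C1CN(S(=O)(=O)c2ccc(C)cc2)CCc2cc(OC)cc(n2)CCN(S(=O)(=O)c2ccc(C)cc2)C1` gives 28000 nM. Compound 3 therefore stands within the usual scatter of both others. Compound 4 `C=C1CN(S(=O)(=O)c2ccc(C)cc2)CCc2cc(O)cc(n2)CCN(S(=O)(=O)c2ccc(C)cc2)C1` differs from compound 3 by hydrogen in place of methyl on an oxygen on an aromatic ring, with hydrogen in place of methyl on an oxygen on an aromatic ring. The closest evidence comes from swapping groups on one aromatic carbon: a 1.1-fold lower number from compound 1 to compound 2 (0.05 log units; within the scatter), a 1.4-fold higher number from compound 1 to compound 3 (0.15 log units; within the scatter) and a 1.6-fold higher number from compound 2 to compound 3 (0.19 log units; within the scatter). None of these steps introduces a hydroxy group, so they are only a rough guide. The expected change is small, a 1.1-fold higher number from compound 3 to compound 4 (0.03 log units; within the scatter), with no shift beyond the scatter anticipated. Compound 4 is estimated at 30000 nM, with an expected range of 15000 nM to 60000 nM.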

Compound 4, solubility: 27000 nM
Compound 4: the middle estimate sits 1.1-fold (0.05 log units) above what was measured, within the range that was stated.
By their numbers in this assay, from the lowest: compounds 2, 1, 4 and 3 (each within the scatter of the next).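

Replacing methoxy with hydroxy gives a 1.0-fold lower number from compound 3 to compound 4 (0.02 log units; within the scatter) in this assay, so losing the methyl from this oxygen leaves the read-out within the scatter. Hydroxy also stays level with the two alkyl groups on this aromatic carbon, with a 1.5-fold higher number from compound 2 to compound 4 (0.18 log units; within the scatter) and a 1.4-fold higher number from compound 1 to compound 4 (0.13 log units; within the scatter) on the same read-out, so none of the four groups shown separates from the others. Nothing measured here offers an explanation for this result. On these data alone, whether an amine or a carboxylic acid on this aromatic carbon would give a step beyond the scatter remains open.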